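A few compounds are considered here, and "the series" means these few. Any claim that something is new, unique, unknown or untested is made for them only; others in the source may bear on it.

Measured so far in an assay on isolated protein for inhibition of Long-chain-fatty-acid--CoA ligase 1 (Homo sapiens), read by mass spectrometry, with a stated time of 90 min, in the presence of a further agent that is not named here; on this read-out lower numbers stand for stronger inhibition and higher numbers for weaker inhibition:
Compound 1 `Cc1cccc(Cc2nc3cc(O[C@H]4CC[C@@H](C(=O)O)CC4)ccc3o2)c1` gives 39 nM.
Compound 2 `Cc1cccc(Cn2nc3cc(O[C@H]4CC[C@@H](C(=O)O)CC4)ccc3c2C)c1` gives 45 nM.
Compound 3 `Cc1cccc(Cc2cc3cc(O[C@H]4CC[C@@H](C(=O)O)CC4)ccc3n2C)c1` gives 400 nM.

Compound 3 therefore stands with the highest number of the three, that is the weakest inhibition, and its gap to compound 2 and to compound 1 lies well beyond the usual scatter. The next compound, compound 4 `Cc1cccc(Cc2c(C(N)=O)c3cc(O[C@H]4CC[C@@H](C(=O)O)CC4)ccc3n2C)c1`, is not yet measured. It differs from compound 3 in one place: carbamoyl in place of hydrogen on an aromatic carbon. Among the measured compounds shown here, no measured pair shows this change, so its effect cannot be read from the data. Compared with compound 3, compound 4 is expected to give a somewhat lower number in this assay, a step of a 2.0-fold lower number from compound 3 to compound 4 (0.30 log units; within the scatter), although a step within the scatter would not surprise. The estimate for compound 4 is 200 nM, with a range from 50 nM to 800 nM.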

Compound 4, half-maximal inhibitory concentration: 600 nM
For compound 4 the middle estimate is 3.0-fold (0.48 log units) below the measured one, within the range that was stated.
By their numbers in this assay, from the lowest: compounds 1 and 2 (each within the scatter of the next); then compounds 3 and 4 (each within the scatter of the next).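

In this assay, placing carbamoyl in place of hydrogen on this aromatic carbon gives a 1.5-fold higher number from compound 3 to compound 4 (0.18 log units; within the scatter). The position therefore carries this group, with its hydrogen-bond donor and acceptor, without a change that can be told apart from the usual scatter, so this single step shows no clear gain or loss in inhibition. No measurement here accounts for this result.

On these data alone, whether a different group on this carbon, such as an amine or a nitrile, would shift the number beyond the scatter remains open.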